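The source may hold more compounds than are shown below. What is called first, only, known or untested is meant among the compounds shown, and "the series" means these compounds.

Measured in a functional assay on A549 cells (Homo sapiens) for cytotoxicity, read by MTT assay, with a stated time of 48 h; on this read-out lower numbers stand for stronger inhibition and higher numbers for weaker inhibition:
Compound 1 `Cc1ccc(Cn2cc(COc3ccc4c(=O)ccoc4c3)nn2)cc1` gives 50700 nM.
Compound 2 `CC(C)(C)c1ccc(Cn2cc(COc3ccc4c(=O)ccoc4c3)nn2)cc1` reaches only the assay limit, > 100000 nM.
Compound 3 `C#CCOc1ccc2c(=O)ccoc2c1` likewise reaches only the assay limit, > 100000 nM.

Compound 2 therefore stands at a limit, not at a number of its own. Two of the three results are of this kind: the limit of > 100000 nM in this assay, at which 2 of the 3 values shown sit. Among the compounds with values here, the only step measured in one place, an at least 1.9-fold higher number from compound 1 to compound 2 (0.29 log units; that floor lies within the scatter), concerns the same aromatic carbon as the change now considered and has a floor that the scatter can account for, so it gives no sign of a shift beyond the scatter.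

Compound 4 `O=c1ccoc2cc(OCc3cn(Cc4ccc(Br)cc4)nn3)ccc12` differs from compound 2 by bromo in place of tert-butyl on an aromatic carbon. Within the data shown here, no measured step swaps a bromo in, so nothing bears directly on this change. The expectation rests on compound 2 sitting at the assay limit. It also rests on compound 1 giving 50700 nM after a step that stayed within scatter. Compound 4 is therefore expected to stay weak, near the limit, with an estimate of 80000 nM in a range from 30000 nM to 200000 nM. The step expected from compound 2 is an at least 1.2-fold lower number from compound 2 to compound 4 (0.09 log units; that floor lies within the scatter), within the scatter.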

Compound 4, half-maximal inhibitory concentration: > 100000 nM
Compound 4: a limit, no number (the forecaster's own chance of this, stated with the estimate: 55%); middle value at least 1.2-fold (0.09 log units) from the limit.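

In this assay compound 4 gives a limit and not a number, so bromo, like tert-butyl, yields no measurable value on this aromatic carbon, para to a large group. Replacing methyl with bromo gives an at least 1.9-fold higher number from compound 1 to compound 4 (0.29 log units; that floor lies within the scatter), so this change shows no shift beyond the scatter. Both steps that would separate bromo from tert-butyl come down to one unreadable comparison, since the two limits cannot be ordered, and the series offers little resolution at this position: the limit of > 100000 nM in this assay, at which 3 of the 4 values shown sit.

As far as these compounds go, whether an amine, a carboxylic acid or a methoxy group on this carbon would give a lower number than compound 1 at 50700 nM remains open. Also open, from the compounds shown here alone, is how a plain hydrogen at this carbon would compare with the methyl of compound 1.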